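A Larger Hydroxylated Ring on an Aromatic Nitrogen

The source may report more compounds than this note shows. Statements on the series, on what has been measured and on what is new or still open speak of the compounds shown alone.

In a functional assay on A-375 cells (Homo sapiens) for cytotoxicity, read by MTT assay, with a stated time of 72 h (a higher number here means a weaker inhibitor, a lower number a stronger inhibitor), compound 1 `O=C1c2c[n+]([O-])c3ccccc3c2C(=O)c2c1c1ccccc1n2Cc1cn(C[C@H](O)CO)nn1` gives 350 nM, and compound 2 `O=C1c2c[n+]([O-])c3ccccc3c2C(=O)c2c1c1ccccc1n2Cc1cn([C@H]2C[C@H](O)[C@@H](CO)O2)nn1` gives 390 nM. Within the data shown here, compound 2 therefore stands level with compound 1, the only other measured compound. Compound 3 `O=C1c2c[n+]([O-])c3ccccc3c2C(=O)c2c1c1ccccc1n2Cc1cn([C@@H]2O[C@H](CO)[C@@H](O)[C@H](O)[C@H]2O)nn1` carries 3,4,5-trihydroxy-6-(hydroxymethyl)oxan-2-yl in place of 4-hydroxy-5-(hydroxymethyl)oxolan-2-yl on an aromatic nitrogen. Among the measured compounds shown here, one measured step bears on this change, the exchange of 2,3-dihydroxypropyl for 4-hydroxy-5-(hydroxymethyl)oxolan-2-yl on an aromatic nitrogen. That step, a 1.1-fold higher number from compound 1 to compound 2 (0.05 log units; within the scatter), stays within the scatter, so a similar exchange of one hydroxylated group for another is not expected to move the number much. For the measured compounds named here, no measured compound carries the six-membered ring, however, so the expectation remains loose. The expected change in this assay is a 1.2-fold higher number from compound 2 to compound 3 (0.09 log units; within the scatter), which would not clearly exceed the scatter. For compound 3 the estimated value is 480 nM, with an expected range of 180 nM to 1300 nM.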

Compound 3, half-maximal inhibitory concentration: 230 nM
For compound 3 the middle estimate is 2.1-fold (0.32 log units) above the measured one; measured number inside the range.
By their numbers in this assay, from the lowest: compounds 3, 1 and 2 (each within the scatter of the next).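

Exchanging 4-hydroxy-5-(hydroxymethyl)oxolan-2-yl for the larger 3,4,5-trihydroxy-6-(hydroxymethyl)oxan-2-yl on the aromatic nitrogen gives a 1.7-fold lower number from compound 2 to compound 3 (0.23 log units; within the scatter) in this assay, and exchanging 2,3-dihydroxypropyl for the same group gives a 1.5-fold lower number from compound 1 to compound 3 (0.18 log units; within the scatter). The open chain, the five-membered ring and the six-membered ring thus all lie within the scatter of one another at this position, so the entering group's 11 heavy atoms and 5 defined stereocentres bring no clear change. No measurement at hand accounts for these numbers.

Going by these compounds, all three groups carry hydroxyl groups, so it remains open whether a plain alkyl chain, an amine or a carboxylic acid on this nitrogen would keep the number in the same range. On these data alone, it is also open whether another arrangement of the stereocentres on the six-membered ring would change it.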